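The source may report more compounds than this note shows. Statements on the series, on what has been measured and on what is new or still open speak of the compounds shown alone.

In a functional assay on SK-BR-3 cells (Homo sapiens) for antiproliferative activity, read by MTT assay, with a stated time of 72 h (on this read-out lower numbers stand for stronger inhibition and higher numbers for weaker inhibition), compound 3 `Cc1cc(N2CCN(C)CC2)nc2ccc(NC(=O)c3ccc(Cl)c(Cl)c3)cc12` gives 6320 nM, the lowest of the two numbers reported here. Compound 1 `CCN1CCN(c2cc(C)c3cc(NC(=O)c4ccc[nH]4)ccc3n2)CC1` gives 13200 nM in this assay, and its gap from compound 3 lies beyond the scatter. Compound 2 `Cc1cc(N(C)C)nc2ccc(NC(=O)c3ccc(Cl)c(Cl)c3)cc12` reaches only a limit of the assay, > 50000 nM, which is the limit of > 50000 nM in this assay, at which 1 of the 3 values shown sits. Going by the values given here, the only measured step within this set is an at least 7.9-fold lower number from compound 2 to compound 3 (0.89 log units; beyond the scatter). Compound 4 `CCN1CCN(c2cc(C)c3cc(NC(=O)c4ccc(Cl)c(Cl)c4)ccc3n2)CC1` differs from compound 3 by methyl in place of hydrogen on a saturated chain carbon bound to an amine nitrogen in a ring. Among the compounds with values here, no measured step bears directly on such a change, so no shift beyond the scatter is expected. Compound 4 is therefore expected to give 5000 nM, with a range from 2500 nM to 12000 nM. The expected step is a 1.3-fold lower number from compound 3 to compound 4 (0.10 log units; within the scatter).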

Compound 4, half-maximal inhibitory concentration: 2160 nM
Beside the measured number, compound 4's estimate is 2.3-fold (0.36 log units) above it; measured number outside the range, below it.
By their numbers in this assay, from the lowest: compound 4; then compound 3; then compound 1. At a limit, above all of these: compound 2.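

In this assay, 4-ethylpiperazin-1-yl in place of 4-methylpiperazin-1-yl gives a 2.9-fold lower number from compound 3 to compound 4 (0.47 log units; beyond the scatter), so a single added methyl on a saturated chain carbon bound to an amine nitrogen in a ring moves the number beyond the scatter. With 4-ethylpiperazin-1-yl in place, 3,4-dichlorophenyl instead of 1H-pyrrol-2-yl gives a 6.1-fold lower number from compound 1 to compound 4 (0.79 log units; beyond the scatter), and the same group instead of dimethylamino gives an at least 23-fold lower number from compound 2 to compound 4 (1.36 log units; beyond the scatter). That last step starts from a limit, not a number: the limit of > 50000 nM in this assay, at which 1 of the 4 values shown sits.

From the compounds shown here alone, whether a propyl group or a longer chain in place of the ethyl would lower the number further stays open.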